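The source may hold more compounds than are shown below. What is called first, only, known or untested is meant among the compounds shown, and "the series" means these compounds.

Of the compounds shown here, two have numbers so far. Compound 1 `Cc1nc(CS(=O)(=O)c2ccc(Br)cc2)c([N+](=O)[O-])n1C` and compound 2 `Cc1nc(CS(=O)(=O)c2ccccc2)c([N+](=O)[O-])n1CC(C)O` were run in an ADME assay on THP-1 cells (Homo sapiens) for cytotoxicity, read by flow cytometry and propidium iodide staining, with a stated time of 72 h; on this read-out higher numbers stand for weaker inhibition and lower numbers for stronger inhibition. In this assay compound 1 gives 326000 nM. In this assay compound 2 gives 418000 nM, a number that sits within the scatter of the number for compound 1, so the two cannot be told apart on this read-out. Compound 3 `Cc1nc(CS(=O)(=O)c2ccc(Br)cc2)c([N+](=O)[O-])n1CC(C)O` has not yet been measured in this assay. It differs from compound 2 in one place (bromo in place of hydrogen on an aromatic carbon). Among the measured compounds shown here, no step between measured compounds isolates this change, and compound 1, which carries the same bromo group, gives a number within the scatter of compound 2. On that basis a step of a 1.2-fold lower number from compound 2 to compound 3 (0.06 log units; within the scatter) is expected, that is, none beyond the scatter. Compound 3 is expected to give 360000 nM in this assay, within a range of 200000 nM to 650000 nM.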

Compound 3, half-maximal inhibitory concentration: 126000 nM
Beside the measured number, compound 3's estimate is 2.9-fold (0.46 log units) above it; measured number outside the range, below it.
By their numbers in this assay, from the lowest: compound 3; then compounds 1 and 2 (each within the scatter of the next).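

In this assay, bromo in place of hydrogen on an aromatic carbon, para to a large group, gives a 3.3-fold lower number from compound 2 to compound 3 (0.52 log units; beyond the scatter) and so registers beyond the scatter where the earlier pair showed no separation. With the 4-bromophenyl group held constant, 1-hydroxyethyl in place of hydrogen on the saturated chain carbon bound to an aromatic nitrogen gives a 2.6-fold lower number from compound 1 to compound 3 (0.41 log units; beyond the scatter) as a second modest step, so compound 3 stands apart from both neighbours although compound 1 and compound 2, which differ in two places, do not separate. No measured evidence accounts for either step.

Whether the bromo step also holds with a methyl group on the aromatic nitrogen remains open, as no pair shown isolates it there. Also open, from the compounds shown here alone, is how chloro or an amine would compare with bromo on the same aromatic carbon.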